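Dropping the 4-Fluorophenyl Group: An Expected Stability Outcome

A few compounds are considered here, and "the series" means these few. Any claim that something is new, unique, unknown or untested is made for them only; others in the source may bear on it.

Compound 1 `CCCCc1nc(=O)c(S(=O)(=O)c2ccc(-c3ccc(F)cc3)cc2)c(O)n1-c1c(OC)cccc1OC` was examined in an ADME assay on microsomes from liver (Mus musculus) for metabolic stability, using NADPH, with a stated time of 10 min (on this read-out higher numbers stand for a more stable compound and lower numbers for a less stable compound), where compound 1 gives 47%. Among the compounds with a number this is the lower of two; compound 3 `CCCCc1[nH]c(=O)c(S(=O)(=O)c2ccc(-n3cc(Cl)ccc3=O)cc2)c(O)c1-c1c(OC)cccc1OC` gives 64% in this assay, a difference beyond the scatter. Compound 2 `CCCCc1[nH]c(=O)c(S(=O)(=O)c2ccc(-c3ccc(F)nc3)cc2)c(O)c1-c1c(OC)cccc1OC` has no number in this assay, recorded only as "not determined" (no result reported). Compound 4 `CCCCc1nc(=O)c(S(=O)(=O)c2ccccc2)c(O)n1-c1c(OC)cccc1OC` differs from compound 1 in one place: hydrogen in place of 4-fluorophenyl on an aromatic carbon. Among the compounds with values here, no measured pair shows this particular change, so nothing direct supports a direction. Because compound 1 sits at 47%, room remains both upward and downward. A modest step, within or barely beyond the scatter, is expected, a number 8 percentage points higher from compound 1 to compound 4 (within the scatter). Compound 4 is accordingly estimated at 55%, with a range from 30% to 80%.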

Compound 4, percent of the compound remaining: 79%
Estimate against measurement, compound 4: 24 percentage points below; measured number inside the range.
By their numbers in this assay, from the lowest: compound 1; then compound 3; then compound 4.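

In this assay, within the data shown here, hydrogen in place of 4-fluorophenyl on this aromatic carbon gives the first direct reading for this position: a number 32 percentage points higher from compound 1 to compound 4 (beyond the scatter). The read-out is therefore clearly sensitive to what this position carries, and the bare ring stands well above the biaryl compound. No measurement given here accounts for the rise. From the compounds shown here alone, whether a plain phenyl without the fluorine, or a small methyl group, would sit nearer compound 1 or compound 4 stays open. So does whether the same change would give a similar step on a different core.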